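Dichlorophenyl on the aromatic nitrogen of compound 1

The source may hold more compounds than are shown below. What is called first, only, known or untested is meant among the compounds shown, and "the series" means these compounds.

Measured so far in a functional assay on PC-12 cells (Rattus norvegicus) for cytotoxicity, read by MTT assay, with stated times of 2 h and 24 h, tested at 5 uM; on this read-out lower numbers stand for a weaker effect and higher numbers for a stronger effect at the one concentration tested:
compound 1, `Oc1cc(C(F)(F)F)ccc1-c1nc(-c2ccccc2O)n(-c2ccc(C(F)(F)F)cc2)n1`, compound 1 gives 90.5%
compound 2, `COc1ccc(-n2nc(-c3ccc(C(F)(F)F)cc3O)nc2-c2ccccc2O)cc1`, compound 2 gives 86.6%
compound 3, `Oc1cc(C(F)(F)F)ccc1-c1nc(-c2ccccc2O)n(-c2ccccc2Cl)n1`, compound 3 gives 90.6%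

Compound 1 stands second highest of the three numbers. Its nearest neighbour is compound 3, with a number 0.1 percentage points higher from compound 1 to compound 3 (within the scatter), and its furthest is compound 2, with a number 3.9 percentage points lower from compound 1 to compound 2 (within the scatter). Going by the values given here, all three numbers therefore sit within the scatter of one another, and no compound can be set above or below the others.

Compound 4, `Oc1cc(C(F)(F)F)ccc1-c1nc(-c2ccccc2O)n(-c2ccc(Cl)cc2Cl)n1`, has not yet been measured. It differs from compound 1 in one place: 2,4-dichlorophenyl in place of 4-(trifluoromethyl)phenyl on an aromatic nitrogen. Among the compounds with values here, the step that bears most directly on it is the one from compound 1 to compound 3, where 2-chlorophenyl took the place of 4-(trifluoromethyl)phenyl on the same aromatic nitrogen and a number 0.1 percentage points higher from compound 1 to compound 3 (within the scatter) resulted. The step from compound 2 to compound 3, also an exchange on that nitrogen, gave a number 4 percentage points higher from compound 2 to compound 3 (within the scatter). Two exchanges of the group on this nitrogen have left the number essentially unchanged, so compound 4 is expected to show no step beyond the scatter, with a number 1.5 percentage points lower from compound 1 to compound 4 (within the scatter) as the estimated change. Compound 4 is thus estimated at 89%, within a range from 78% to 96%.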

Compound 4, a percentage reported as activity, at one concentration (the size of the read-out at that concentration, not a potency): 86.7%
For compound 4 the middle estimate is 2.3 percentage points above the measured one; the measured number falls inside the stated range.
By their numbers in this assay, from the lowest: compounds 2, 4, 1 and 3 (each within the scatter of the next).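

In this assay, 2,4-dichlorophenyl on the aromatic nitrogen gives a number 3.8 percentage points lower from compound 1 to compound 4 (within the scatter) when it replaces 4-(trifluoromethyl)phenyl and a number 0.1 percentage points higher from compound 2 to compound 4 (within the scatter) when it replaces 4-methoxyphenyl, so a group carrying two chloro substituents also leaves the read-out within the scatter at this position. The result also adds a comparison within the chlorinated series: chloro in place of hydrogen on an aromatic carbon of the 2-chlorophenyl group gives a number 3.9 percentage points lower from compound 3 to compound 4 (within the scatter) and so does not separate the two chlorinated compounds. Nothing available accounts for this lack of separation among the four groups on this nitrogen.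

As far as these compounds go, all four compounds carry a substituted phenyl group on this nitrogen, so it remains open whether an aminophenyl or carboxyphenyl group, or a cyclohexyl group or longer alkyl chain in place of the phenyl ring, would give a step beyond the scatter. All four also keep both hydroxy groups of the core, and the compounds shown leave open what an amine or a methoxy group in place of either hydroxy group would do.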